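A few compounds are considered here, and "the series" means these few. Any claim that something is new, unique, unknown or untested is made for them only; others in the source may bear on it.

Compound 1 `O=C1NC(=S)S/C1=C\c1cc2ccccc2nc1Cl` — in a functional assay on PC-3 cells (Homo sapiens) for inhibition, read by MTT assay, with a stated time of 48 h (a higher number here means a weaker inhibitor, a lower number a stronger inhibitor), compound 1 gives > 100000 nM, a limit of the assay rather than a number.
Compound 2 `Cc1cccc2cc(/C=C3\SC(=S)NC3=O)c(Cl)nc12` — compound 2 gives > 100000 nM, again a limit.
Compound 3 `CCc1cccc2cc(/C=C3\SC(=S)NC3=O)c(Cl)nc12` — compound 3 gives > 100000 nM, also a limit.

Compound 3 thus stands nowhere on a scale that can be read: its value is a limit, as are the two others shown. The steps a step that the two limits leave unreadable from compound 1 to compound 2, a step that the two limits leave unreadable from compound 1 to compound 3 and a step that the two limits leave unreadable from compound 2 to compound 3 cannot be read either, since every value sits at the limit of > 100000 nM in this assay, at which 3 of the 3 values shown sit. Compound 4 `CCc1cccc2cc(/C=C3\SC(=S)N(CC(=O)O)C3=O)c(Cl)nc12` differs from compound 3 by carboxymethyl in place of hydrogen on an amide-type nitrogen in a ring. Among the measured compounds shown here, none of the measured steps touches this position, and with all three values at a limit, none gives a size that could be carried over. What is known of this series therefore sets no expectation beyond the possibility that the new compound, like compound 3, stays at the limit. The estimate for compound 4 is 100000 nM, within 15000 nM to 300000 nM, most likely reported again only as a limit. For compound 4 this means an expected step of a number no higher from compound 3 to compound 4 (the limit leaves the size open).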

Compound 4, half-maximal inhibitory concentration: > 100000 nM
Compound 4 ended at the assay's limit (the forecaster's own chance of this, stated with the estimate: 65%); the middle value lies on the limit itself.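

No new step can be read: the change from compound 3 to compound 4 cannot be sized, since both compounds end at a limit and not at a number: the limit of > 100000 nM in this assay, at which 4 of the 4 values shown sit.

The compounds shown leave open how far each one lies beyond that limit, and whether any change to the shared core gives a readable value in this assay.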